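The compounds below may be only part of what the source reports. "The series", "measured", "known", "first", "only" and "open" are said of these compounds alone.

Measured compounds:
compound 1 `CN(C)CCn1cnnc1-c1cc(Oc2ccc(NC(=O)N/N=C/c3ccccc3)cc2F)ccn1`, 1780 nM in a functional assay on NCI-H460 cells (Homo sapiens) for cytotoxicity, read by MTT assay, with a stated time of 72 h; a higher number here means a weaker inhibitor, a lower number a stronger inhibitor
compound 2 `CN(C)CCn1cnnc1-c1cc(Oc2ccc(NC(=O)N/N=C/c3c(O)ccc4ccccc34)cc2F)ccn1`, 890 nM in this assay

Compound 2 holds the lowest of the two numbers in this assay; its nearest neighbour is compound 1, and the step of a 2.0-fold lower number from compound 1 to compound 2 (0.30 log units; within the scatter), so the two cannot be separated on the present data.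

Compound 3 `CN(C)CCn1cnnc1-c1cc(Oc2ccc(NC(=O)N/N=C/c3cccc(O)c3)cc2F)ccn1` is not yet measured. It differs from compound 2 as follows:
3-hydroxyphenyl in place of 2-hydroxynaphthalen-1-yl on a carbon with a double bond to nitrogen

Going by the values given here, the only measured step that bears on this position is a 2.0-fold lower number from compound 1 to compound 2 (0.30 log units; within the scatter), which stayed within the scatter, so the carbon with a double bond to nitrogen has so far tolerated exchange of its aryl group without a clear effect. Among the compounds with values here, with no measured example of 3-hydroxyphenyl, the expectation for compound 3 is no step beyond the scatter, leaning toward the value of compound 1 because 1780 nM was recorded for the smaller aryl group. Compound 3 is therefore estimated at 1300 nM, range 500 nM to 3500 nM. The expected step is a 1.5-fold higher number from compound 2 to compound 3 (0.16 log units; within the scatter).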

Compound 3, half-maximal inhibitory concentration: 780 nM
Compound 3: the middle estimate sits 1.7-fold (0.22 log units) above what was measured, within the range that was stated.
By their numbers in this assay, from the lowest: compounds 3, 2 and 1 (each within the scatter of the next, the first and the last beyond it).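

In this assay, hydroxy in place of hydrogen on an aromatic carbon gives a 2.3-fold lower number from compound 1 to compound 3 (0.36 log units; beyond the scatter), a modest step and the first at this position to pass the scatter. 3-hydroxyphenyl in place of 2-hydroxynaphthalen-1-yl gives a 1.1-fold lower number from compound 2 to compound 3 (0.06 log units; within the scatter), so a single aromatic ring carrying hydroxy cannot be told apart from the larger two-ring group, and the second ring shows no measurable contribution here. No evidence is available on why the numbers fall as they do.

On these data alone, it remains open whether this modest step depends on hydroxy itself or would also follow from methoxy, an amine or a carboxylic acid on the same phenyl ring. The effect of placement on the ring also remains open, as 2-hydroxyphenyl and 4-hydroxyphenyl are not among the compounds shown.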